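This account rests on a few compounds, and the source may have more. Where it says the series, first, only, none or still open, it means among the compounds named here.

Measured so far:
compound 1 `CN(C)c1ccc(/C=C(\C(=O)c2ccc(Cl)cc2)S(=O)(=O)c2ccc(Br)cc2)cc1`: > 100000 nM
compound 2 `Cc1ccc(CS/C(=C/c2ccc(Br)cc2)C(=O)c2ccc(Cl)cc2)cc1`: 10000 nM

Among the compounds with values here, in a functional assay on DU-145 cells (Homo sapiens) for inhibition, read by trypan blue exclusion, with a stated time of 96 h (a lower number here means a stronger inhibitor of growth, a higher number a weaker inhibitor of growth), compound 2 gives 10000 nM, the only number in the set. For compound 1 the result in this assay is a limit, > 100000 nM, not a number; (the limit of > 100000 nM in this assay, at which 1 of the 2 values shown sits). Compound 3 `Cc1ccc(CS/C(=C/c2ccc(N(C)C)cc2)C(=O)c2ccc(Cl)cc2)cc1` is not yet measured; it differs from compound 2 by dimethylamino in place of bromo on an aromatic carbon. Within the data shown here, no step between measured compounds is available to size this change, so the expectation rests on compound 2 alone. A step from compound 2 to compound 3 of a 2.0-fold higher number from compound 2 to compound 3 (0.30 log units; within the scatter) is expected, a mild weakening that may not exceed the scatter. For compound 3 the estimate is 20000 nM, within 5000 nM to 100000 nM.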

Compound 3, concentration for 50% growth inhibition: > 100000 nM
Compound 3: a limit, no number; the forecaster's own chance of this, stated with the estimate: 25%; middle value at least 5.0-fold (0.69 log units) away from the limit.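

In this assay, within the data shown here, the change from 4-bromophenyl to 4-(dimethylamino)phenyl gives the first readable step, and it lies beyond the scatter: an at least 10-fold higher number from compound 2 to compound 3 (1.00 log units; beyond the scatter). The result for compound 3 is a limit, not a number, so this step has a lower bound only. Among these compounds, compound 2 remains the only compound with a number: the limit of > 100000 nM in this assay, at which 2 of the 3 values shown sit.

The two limits leave the step between compound 1 and compound 3 unreadable. On these data alone, whether a chloro, methoxy or unsubstituted amino group on this aromatic carbon would stay close to compound 2 remains open.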